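Aryl Swap on the Aromatic Nitrogen: Compound 4 Ahead

This account rests on a few compounds, and the source may have more. Where it says the series, first, only, none or still open, it means among the compounds named here.

In a functional assay on PC-12 cells (Rattus norvegicus) for cytotoxicity, read by MTT assay, with stated times of 2 h and 24 h, tested at 1 uM (on this read-out higher numbers stand for a stronger effect at the one concentration tested and lower numbers for a weaker effect), compound 3 `Cc1ccc(-n2nc(-c3ccc(C(F)(F)F)cc3O)nc2-c2ccccc2O)c(C)c1` gives 73.7%, the highest of the three numbers, while compound 1 `CC(C)c1ccc(-n2nc(-c3ccc(C(F)(F)F)cc3O)nc2-c2ccccc2O)cc1` gives 69.7% and compound 2 `COc1ccc(-n2nc(-c3ccc(C(F)(F)F)cc3O)nc2-c2ccccc2O)cc1` gives 69%. The steps of a number 4 percentage points higher from compound 1 to compound 3 (within the scatter) and a number 4.7 percentage points higher from compound 2 to compound 3 (within the scatter) both fall within the scatter, as does a number 0.7 percentage points lower from compound 1 to compound 2 (within the scatter), so the three compounds stand level. Compound 4 `Oc1cc(C(F)(F)F)ccc1-c1nc(-c2ccccc2O)n(-c2ccc(Cl)cc2Cl)n1` differs from compound 3 by 2,4-dichlorophenyl in place of 2,4-dimethylphenyl on an aromatic nitrogen. For the measured compounds named here, the bearing steps are the three swaps of the aryl group on the aromatic nitrogen, none of which moved this assay beyond the scatter; no measured step brings in chlorine. No shift beyond the scatter is therefore expected. Compound 4 is estimated at 71%, from 61% to 81%. This expectation corresponds to a step of a number 2.7 percentage points lower from compound 3 to compound 4 (within the scatter).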

Compound 4, a percentage reported as activity, at one concentration (the size of the read-out at that concentration, not a potency): 69%
Compound 4: the middle estimate sits 2 percentage points above what was measured, and the stated range covers the measured number.
By their numbers in this assay, from the lowest: compounds 2, 4, 1 and 3 (each within the scatter of the next).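

Chlorine now enters the aryl group on the aromatic nitrogen, and in this assay the new steps all stay within the scatter: a number 4.7 percentage points lower from compound 3 to compound 4 (within the scatter) and no change at the digits printed from compound 2 to compound 4 (within the scatter) and a number 0.7 percentage points lower from compound 1 to compound 4 (within the scatter). At this position, 2,4-dichlorophenyl therefore stands level with the 2,4-dimethylphenyl, 4-methoxyphenyl and 4-isopropylphenyl groups, extending the flat picture from carbon and oxygen substituents to a halogen. Nothing available explains this level outcome. As far as these compounds go, whether an amine or a carboxylic acid on this aryl group would leave the read-out level remains open. From the compounds shown here alone, the 2-hydroxyphenyl and trifluoromethyl groups stay unchanged throughout, so their contribution is also open.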